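This account rests on a few compounds, and the source may have more. Where it says the series, first, only, none or still open, it means among the compounds named here.

Measured so far:
compound 1 `O=C(CN1CCN(c2ccc(F)cc2)CC1)Nc1nc2c(o1)CCCC2`, 5400 nM
compound 2 `Cc1ccc(N2CCN(CC(=O)Nc3nc4c(s3)CCCC4)CC2)cc1`, > 10000 nM

Going by the values given here, in an assay on isolated protein for inhibition of long-chain fatty acid transport protein 1 (Mus musculus), read by scintillation counting, with a stated time of 20 min (on this read-out lower numbers stand for stronger inhibition and higher numbers for weaker inhibition), compound 1 gives 5400 nM, the only number in the set. Compound 2 gives only > 10000 nM in this assay, a limit of the assay and not a number; (the limit of > 10000 nM in this assay, at which 1 of the 2 values shown sits). Compound 1 thus stands as the one compound with a measured number, and no step between two measured compounds is available, so nothing in the shown data fixes the size or direction of a change at this position.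

Compound 3 `O=C(CN1CCN(c2ccc(F)cn2)CC1)Nc1nc2c(o1)CCCC2` differs from compound 1 by 5-fluoropyridin-2-yl in place of 4-fluorophenyl on an amine nitrogen in a ring; the rest of the shared core is kept. Without a comparable measured step, the change is expected to stay within the scatter, with an expected step of a 1.3-fold higher number from compound 1 to compound 3 (0.11 log units; within the scatter) in this assay. Compound 3 is estimated at 7000 nM in this assay, within a range from 2500 nM to 20000 nM.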

Compound 3, half-maximal inhibitory concentration in the long-chain fatty acid transport protein 1 assay: 1700 nM
Compound 3: middle estimate off by 4.1-fold (0.61 log units), on the high side; the whole stated range lies above it.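

In the long-chain fatty acid transport protein 1 assay compound 1 gives 5400 nM and compound 3 gives 1700 nM. Going by these compounds alone, the first measured step at this position shows that the ring on the amine nitrogen is not indifferent in the long-chain fatty acid transport protein 1 assay: 5-fluoropyridin-2-yl in place of 4-fluorophenyl gives a 3.2-fold lower number from compound 1 to compound 3 (0.50 log units; beyond the scatter) and thus stronger inhibition. In a physicochemical assay for lipophilicity, in phosphate buffer, measured as octanol-water partition, at pH 7.4 (on this read-out lower numbers stand for lower lipophilicity and higher numbers for higher lipophilicity), compound 1 gives 3 and compound 3 gives 2.7. In the physicochemical assay the same change gives a number 0.30 log units lower from compound 1 to compound 3 (within the scatter) and leaves the two compounds not distinguishable on that read-out. Nothing among the data shown accounts for the step in inhibition.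

A single step cannot show whether the ring nitrogen alone carries this gain or whether it depends on the fluorine that both compounds share. On these data alone, how a pyridin-2-yl group without fluorine, a 5-chloropyridin-2-yl group or a pyrimidin-2-yl ring at the same place would read in the long-chain fatty acid transport protein 1 assay stays open.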